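A few compounds are considered here, and "the series" means these few. Any claim that something is new, unique, unknown or untested is made for them only; others in the source may bear on it.

Compound 1 `CCOC(=O)C1(Cc2ccccc2)CN(c2ccccc2)Cc2nnn(Cc3ccccc3Cl)c21`, compound 2 `CCOC(=O)C1(Cc2ccccc2)CN(c2ccccc2)Cc2nnn(Cc3ccc(Cl)c(Cl)c3)c21` and compound 3 `CCOC(=O)C1(Cc2ccccc2)CN(c2ccccc2)Cc2nnn(CCCCCO)c21` share one core and differ only in the group on the saturated chain carbon bound to an aromatic nitrogen. In an ADME assay on HEL cells (Homo sapiens) for cytotoxicity, read by microscopy, with a stated time of 3 days (a lower number here means that less compound is tolerated, a higher number that more compound is tolerated), compound 1 gives > 100000 nM, a limit of the assay. Compound 2 likewise gives > 100000 nM, a limit. Compound 3 also gives > 100000 nM, a limit, so that compound 3 stands with the others at the limit of > 100000 nM in this assay, at which 3 of the 3 values shown sit. The steps a step that the two limits leave unreadable from compound 1 to compound 2, a step that the two limits leave unreadable from compound 1 to compound 3 and a step that the two limits leave unreadable from compound 2 to compound 3 are therefore unreadable. Compound 4 `CCCCCCCCn1nnc2c1C(Cc1ccccc1)(C(=O)OCC)CN(c1ccccc1)C2` carries the change (propyl in place of hydroxy on a saturated chain carbon, five bonds along the chain from an aromatic nitrogen). Among the compounds with values here, no measured step bears readably on this change, so no step beyond the scatter is expected in this assay. Compound 4 is estimated at 100000 nM, between 30000 nM and 300000 nM, an expected step of a number no higher from compound 3 to compound 4 (the limit leaves the size open).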

Compound 4, minimum cytotoxic concentration: >= 20000 nM
Compound 4: no number, only a limit (the forecaster's own chance of this, stated with the estimate: 85%); the middle value is on the limit's open side.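

In this assay, within the data shown here, compound 4 gives >= 20000 nM, a limit of the assay, so no step between compound 1, compound 2, compound 3 and compound 4 can be read. The compounds shown leave open whether the group on the saturated chain carbon bound to an aromatic nitrogen changes the concentration tolerated.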